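The source may report more compounds than this note shows. Statements on the series, on what has been measured and on what is new or still open speak of the compounds shown alone.

Working notes on the series. In a functional assay on HepG2 cells (Homo sapiens), read by MTT assay, with a stated time of 48 h (a lower number here means a stronger inhibitor, a higher number a weaker inhibitor), compound 1 (`CCOC(=O)CN(C)C(=O)c1ccc(C(CC)(CC)c2ccc(OCC(O)C(C)(C)C)c(C)c2)n1CC`) gives > 50000 nM, which is a limit and not a number. In this assay compound 2 (`CCn1c(C(=O)N(C)CCC#N)ccc1C(CC)(CC)c1ccc(OCC(O)C(C)(C)C)c(C)c1`) gives > 50000 nM, which is also a limit, so its position is known only as the limit of > 50000 nM in this assay, at which 2 of the 2 values shown sit. For the measured compounds named here, the one measured step is a step that the two limits leave unreadable from compound 1 to compound 2, and it supplies no size to carry forward.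

Compound 3 (`CC[C@@H](C)[C@H](NC(=O)c1ccc(C(CC)(CC)c2ccc(OCC(O)C(C)(C)C)c(C)c2)n1CC)C(=O)O`) follows from compound 2 through (1-carboxy-2-methylbutyl)amino in place of (2-cyanoethyl)(methyl)amino on a carbonyl carbon. Going by the values given here, no measured step covers this change, and the only guide is that both measured compounds sit at the limit. In this assay a small shift at most is expected, towards stronger inhibition if there is one, and the estimated step is an at least 1.2-fold lower number from compound 2 to compound 3 (0.09 log units; that floor lies within the scatter). For compound 3 the expected value is 40000 nM, with an estimated range from 12000 nM to 90000 nM.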

Compound 3, half-maximal inhibitory concentration: 127 nM
Beside the measured number, compound 3's estimate is 310-fold (2.50 log units) above it, and the stated range ends above it.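

In this assay, for the compounds shown here, the group on the carbonyl carbon is the first place where a change gives a readable size: (1-carboxy-2-methylbutyl)amino in place of (2-cyanoethyl)(methyl)amino gives an at least 390-fold lower number from compound 2 to compound 3 (2.59 log units; beyond the scatter). The same group in place of ((ethoxycarbonyl)methyl)(methyl)amino gives an at least 390-fold lower number from compound 1 to compound 3 (2.59 log units; beyond the scatter). The step between the two earlier compounds cannot be read, and compound 1 and compound 2 remain limits and not numbers: the limit of > 50000 nM in this assay, at which 2 of the 3 values shown sit.

The entering group differs from both leaving groups in several features at once, and the compounds shown do not assign the step to the carboxylic acid, the branched chain, the amide hydrogen or the defined stereocentres. Going by these compounds, how a carboxymethylamino group or a primary carboxamide would read at this position remains open.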